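A few compounds are considered here, and "the series" means these few. Any claim that something is new, unique, unknown or untested is made for them only; others in the source may bear on it.

Of the compounds shown here, three sharing one core have been tested in a functional assay on HeLa cells (Homo sapiens) for antiproliferative activity, read by CCK-8 assay, with a stated time of 72 h; on this read-out lower numbers stand for stronger inhibition and higher numbers for weaker inhibition. Compound 1 (`CCOc1ccc(-c2cncnc2-c2cc(OC)c(OC)c(OC)c2)cc1F`) gives 470 nM and compound 2 (`CCOc1ccc(-c2cncnc2-c2cc(OC)c(OC)c(OC)c2)cc1C(F)(F)F`) gives 790 nM. Compound 3 (`COc1cc(-c2ncncc2-c2ccc(OCC(F)(F)F)cc2)cc(OC)c1OC`) gives 10200 nM, the highest number of the three, which makes it the weakest inhibitor here. Compound 4 (`COc1cc(-c2ncncc2-c2ccc(B(O)O)cc2)cc(OC)c1OC`) has not been measured yet. Its structure departs from compound 3 as follows: a group of 3 heavy atoms (1 boron, 2 oxygen; no ring) in place of a group of 6 heavy atoms (2 carbon, 1 oxygen, 3 fluorine; no ring), on an aromatic carbon. Among the measured compounds shown here, the group leaving is 2,2,2-trifluoroethoxy, and the group entering contains boron, a change that no measured step covers. For the measured compounds named here, the one measured step, a 1.7-fold higher number from compound 1 to compound 2 (0.23 log units; within the scatter), involves trifluoromethyl in place of fluoro, so it says nothing direct about this swap. Compound 3 alone carries 2,2,2-trifluoroethoxy and stands apart at 10200 nM, so removing that group is expected to lower the number, though this is only a weak guide. The expected step is a 5.1-fold lower number from compound 3 to compound 4 (0.71 log units; beyond the scatter), with wide uncertainty. For compound 4 the estimated value is 2000 nM, with an expected range from 200 nM to 15000 nM.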

Compound 4, half-maximal inhibitory concentration: 4000 nM
Compound 4: middle estimate off by 2.0-fold (0.30 log units), on the low side; the measured number falls inside the stated range.
By their numbers in this assay, from the lowest: compounds 1 and 2 (each within the scatter of the next); then compound 4; then compound 3.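

In this assay, replacing 2,2,2-trifluoroethoxy with the smaller boron-bearing group on the aromatic carbon para to a large group gives a 2.6-fold lower number from compound 3 to compound 4 (0.41 log units; beyond the scatter), a modest change but one beyond the scatter. Among the compounds shown here, this is the first measured change at this position, and it shows that activity here responds to the group present, with inhibition stronger for the boron-bearing group than for 2,2,2-trifluoroethoxy. The entering group has 2 hydrogen-bond donors where the leaving group has 0, yet no data here explain the shift.

With only these two groups compared at this position, no trend can be drawn. A carboxylic acid, an amine or a hydroxyl in the same place would help show whether boron itself matters or whether other small groups give a similar result.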